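The source may hold more compounds than are shown below. What is called first, only, known or untested is meant among the compounds shown, and "the series" means these compounds.

Compound 1 `CN(C)c1ncnc2c1c(-c1cc3ccccc3o1)cn2[C@@H]1O[C@H](CO)[C@@H](O)[C@H]1O` gives in a functional assay on A549 cells (Homo sapiens), read by MTT assay, with a stated time of 72 h (on this read-out higher numbers stand for weaker inhibition and lower numbers for stronger inhibition), a value of > 20000 nM, which is a limit of the assay and not a number.
Compound 2 `Cc1ncnc2c1c(-c1cc3ccccc3o1)cn2[C@@H]1O[C@H](CO)[C@@H](O)[C@H]1O` gives in this assay a value of > 20000 nM, again a limit.
Compound 3 `CNc1ncnc2c1c(-c1cc3ccccc3o1)cn2[C@@H]1O[C@H](CO)[C@@H](O)[C@H]1O` gives in this assay a value of > 20000 nM, also a limit.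

Going by the values given here, compound 2 therefore stands only at a limit, with no measured number behind it, and every value so far sits at the same limit (the limit of > 20000 nM in this assay, at which 3 of the 3 values shown sit). The steps a step that the two limits leave unreadable from compound 1 to compound 2, a step that the two limits leave unreadable from compound 1 to compound 3 and a step that the two limits leave unreadable from compound 2 to compound 3 cannot be read in size or direction. Compound 4 `C#Cc1cn([C@@H]2O[C@H](CO)[C@@H](O)[C@H]2O)c2ncnc(C)c12` differs from compound 2 by ethynyl in place of 1-benzofuran-2-yl on an aromatic carbon. Among the compounds with values here, none of the measured steps touches this change, so no direction can be read from them. Compound 4 is expected to give about 20000 nM, between 3000 nM and 100000 nM. The expected step of a number no higher from compound 2 to compound 4 (the limit leaves the size open) is thus essentially none beyond the scatter, most likely another limit.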

Compound 4, half-maximal inhibitory concentration: 19200 nM
The estimate for compound 4 lay 1.0-fold (0.02 log units) above the measured number, and the stated range covers the measured number.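

In this assay, going by these compounds alone, compound 4 is the first compound here to give a measured number and not a limit, with ethynyl on this aromatic carbon. Ethynyl in place of 1-benzofuran-2-yl gives an at least 1.0-fold lower number from compound 2 to compound 4 (0.01 log units; that floor lies within the scatter), so no real gain is shown, though the true size of the change stays open. The step has only a floor because compound 2 gives a limit, not a number: the limit of > 20000 nM in this assay, at which 3 of the 4 values shown sit.

As far as these compounds go, whether an aminomethyl group or a longer alkyne chain on this carbon would lower the number remains open. So does whether ethynyl would give a similar number with methylamino or dimethylamino in place of the methyl.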